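Compound 4: Exchanging the Benzyl Group of Compound 1

The source may hold more compounds than are shown below. What is called first, only, known or untested is meant among the compounds shown, and "the series" means these compounds.

Compound 1 `CN(CCNCc1cn(Cc2ccccc2)nn1)CCNc1ccnc2cc(Cl)ccc12` was tested in a functional assay on NCI-H460 cells (Homo sapiens) for antiproliferative activity, read by sulforhodamine B assay, with a stated time of 72 h (on this read-out higher numbers stand for weaker inhibition and lower numbers for stronger inhibition), where compound 1 gives 32000 nM. Among the compounds with values here, of the three compounds measured so far this is the lowest number. Compound 2 `CN(CCNCc1cn(-c2nc3ccccc3[nH]2)nn1)CCNc1ccnc2cc(Cl)ccc12` gives 33000 nM, and the step of a 1.0-fold higher number from compound 1 to compound 2 (0.01 log units; within the scatter) shows that swapping the benzyl group for a benzimidazolyl group on the aromatic nitrogen left the read-out where it was. Within the data shown here, compound 3 `CN(CCNCc1cn(CC(=O)Nc2cccc3ccc(O)cc23)nn1)CCNc1ccnc2cc(Cl)ccc12` gives 67000 nM, the furthest of the three from compound 1 and beyond the scatter; no single-point step is recorded for that pair, so only the two values themselves can be compared.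

Compound 4 `CN(CCNCc1cn(CCCn2nn[nH]c2=O)nn1)CCNc1ccnc2cc(Cl)ccc12` differs from compound 1 by a group of 8 heavy atoms (3 carbon, 4 nitrogen, 1 oxygen; one five-membered aromatic ring with 4 hetero atoms) in place of a group of 6 heavy atoms (6 carbon; one six-membered aromatic ring of carbon only), on a saturated chain carbon bound to an aromatic nitrogen. Among the measured compounds shown here, no measured step covers this exact exchange. For the measured compounds named here, the only step that touches the same position, from compound 1 to compound 2, stayed within the scatter, and the whole series sits in a narrow band of weak inhibition. On that basis compound 4 is expected to show a step of a 1.3-fold higher number from compound 1 to compound 4 (0.10 log units; within the scatter), that is, no movement beyond the scatter in either direction. Compound 4 is therefore estimated at 40000 nM in this assay, with a range from 17000 nM to 95000 nM.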

Compound 4, half-maximal inhibitory concentration: > 200000 nM
Compound 4 gave a limit, no number; the forecaster's own chance of this, stated with the estimate: 15%; middle value at least 5.0-fold (0.69 log units) away from the limit.
By their numbers in this assay, from the lowest: compounds 1 and 2 (each within the scatter of the next); then compound 3. At a limit, above all of these: compound 4.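

In this assay, compound 4 gave only a limit of the assay, not a number: the limit of > 200000 nM in this assay, at which 1 of the 4 values shown sits.

Until now this position had shown no response, as a 1.0-fold higher number from compound 1 to compound 2 (0.01 log units; within the scatter) stayed within the scatter, but exchanging the phenyl for the group with a five-membered aromatic ring with 4 hetero atoms gives an at least 6.2-fold higher number from compound 1 to compound 4 (0.79 log units; beyond the scatter), so what sits here can weaken inhibition beyond the scatter. The same holds from the other side, with an at least 6.0-fold higher number from compound 2 to compound 4 (0.78 log units; beyond the scatter), so the new group falls short of both the benzyl compound and the benzimidazolyl compound, and the steps printed for it give only a lower bound on the true size of the loss.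

The compounds shown leave open whether the loss follows from the ring with 4 hetero atoms itself or from the chain that carries it, since a phenyl on the same chain does not stand among them. They also leave open whether a carboxylic acid or an amine at the end of that chain would weaken inhibition to the same extent.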